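Cyclopropyl sulfoximine replacing the trifluoromethyl sulfoximine on the shared core

This account rests on a few compounds, and the source may have more. Where it says the series, first, only, none or still open, it means among the compounds named here.

Compound 1 `CC#C[C@H]1CN(S(=O)(=O)c2ccc(N)nc2)CCN1c1ccc(S(=O)(=NC)C(F)(F)F)cc1` gives the highest number of the three measured in an assay on cells (Hepatocyte) for inhibition of glucokinase regulatory protein (Mus musculus), with stated times of 20 min and 40 min (on this read-out lower numbers stand for an effect already at smaller amounts and higher numbers for an effect only at larger amounts of compound), at 2060 nM; compound 3 `CC#C[C@H]1CN(S(=O)(=O)c2ccc(N)nc2)CCN1c1ccc(S(=O)(=O)NCC2CC2)cc1` gives 271 nM and compound 2 `C#CCC(O)(c1ccc(N2CCN(S(=O)(=O)c3ccc(N)nc3)C[C@@H]2C#CC)cc1)C(F)(F)F` gives 130 nM. Compound 4 `CC#C[C@H]1CN(S(=O)(=O)c2ccc(N)nc2)CCN1c1ccc(S(=N)(=O)C2CC2)cc1` differs from compound 1 by a group of 6 heavy atoms (3 carbon, 1 nitrogen, 1 oxygen, 1 sulfur; one three-membered non-aromatic ring of carbon only) in place of a group of 8 heavy atoms (2 carbon, 1 nitrogen, 1 oxygen, 3 fluorine, 1 sulfur; no ring), on an aromatic carbon. Both measured steps away from compound 1 lowered the number: a 16-fold lower number from compound 1 to compound 2 (1.20 log units; beyond the scatter) and a 7.6-fold lower number from compound 1 to compound 3 (0.88 log units; beyond the scatter). The closer precedent is the step to compound 3, which also brings a three-membered ring of carbon only onto the same aromatic carbon, so a step of similar size and direction is expected for compound 4, a 5.9-fold lower number from compound 1 to compound 4 (0.77 log units; beyond the scatter). Compound 4 is therefore estimated at 350 nM in this assay , within 120 nM to 1000 nM.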

Compound 4, half-maximal effective concentration: 208 nM
Beside the measured number, compound 4's estimate is 1.7-fold (0.23 log units) above it, within the range that was stated.
By their numbers in this assay, from the lowest: compounds 2, 4 and 3 (each within the scatter of the next, the first and the last beyond it); then compound 1.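

In this assay, the group carrying a three-membered ring of carbon only gives a 9.9-fold lower number from compound 1 to compound 4 (1.00 log units; beyond the scatter), so a gain of this size at this aromatic carbon does not need the larger group of compound 3. The remaining comparisons read a 1.3-fold lower number from compound 3 to compound 4 (0.11 log units; within the scatter) and a 1.6-fold higher number from compound 2 to compound 4 (0.20 log units; within the scatter), which leaves compound 4 unseparated from either neighbour. No data here give a reason for these differences.

From the compounds shown here alone, whether the three-membered ring itself matters remains open: a methyl or a cyclobutyl group in its place would test that.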